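The source may report more compounds than this note shows. Statements on the series, on what has been measured and on what is new or still open speak of the compounds shown alone.

Compound 1 `O=C(NCc1ccccc1)c1cn(-c2ccccc2)nc1-c1cccnc1` gave no result in a functional assay on MCF7 cells (Homo sapiens) for cytotoxicity, read by MTT assay, with a stated time of 48 h; on this read-out lower numbers stand for stronger inhibition and higher numbers for weaker inhibition: its entry reads "nd(insoluble)" (no result reported). Compound 2 `CC(C)(C)c1ccc(OC(=O)c2cn(-c3ccccc3)nc2-c2cccnc2)cc1` sits at the assay limit in this assay, > 100000 nM; this is a limit and not a number. Compound 3 `O=C(NCc1ccccc1)c1cn(-c2ccccc2)nc1-c1ccncc1` likewise sits at the limit in this assay, with > 100000 nM, again a limit rather than a number. Of the three entries, then, two are limits and one is without a number: the limit of > 100000 nM in this assay, at which 2 of the 3 values shown sit. Among the measured compounds shown here, compound 3 therefore stands nowhere on a scale of numbers; it has a limit only, and no step between measured compounds can be drawn from it.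

Compound 4 `O=C(O)c1cn(-c2ccccc2)nc1-c1ccncc1` is not yet measured. It differs from compound 3 in one place: hydroxy in place of benzylamino on a carbonyl carbon. Nothing measured in the series speaks for a change in this assay beyond the scatter; only a measurable value for compound 4 would register as a step away from the limit of compound 3. The step expected is a step that the limit leaves unreadable from compound 3 to compound 4, none beyond the scatter, with a limit the most likely outcome. Compound 4 is expected to give 150000 nM in this assay, estimated within 50000 nM to 500000 nM.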

Compound 4, half-maximal inhibitory concentration: > 100000 nM
Compound 4: a limit, no number; the forecaster's own chance of this, stated with the estimate: 85%; the middle value lies beyond the limit too.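

In this assay compound 4 gives > 100000 nM, which is a limit and not a number. Compound 3 also stands at a limit, so no step can be read between compound 3 and compound 4. The compounds shown leave open whether any group on this carbonyl carbon gives a measurable value, since none of them has a number: the limit of > 100000 nM in this assay, at which 3 of the 4 values shown sit.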